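This account rests on a few compounds, and the source may have more. Where it says the series, first, only, none or still open, it means among the compounds named here.

Working notes on the series, with cytotoxicity read in a functional assay on NCI-H1299 cells (Homo sapiens) for cytotoxicity, read by resazurin assay, with a stated time of 72 h; a lower number here means a stronger inhibitor, a higher number a weaker inhibitor. Compound 1 `O=C(/C=C/c1ccc(OCCCCCO[N+](=O)[O-])c(O)c1)OCCCCCO[N+](=O)[O-]` reaches only the limit of this assay, giving > 50000 nM. Compound 3 `COc1cc(/C=C/C(=O)OCCCCCO[N+](=O)[O-])ccc1OCCCCCO[N+](=O)[O-]` differs from compound 1 by methyl in place of hydrogen on an oxygen on an aromatic ring. At the limit as well, compound 3 gives > 50000 nM. The step that the two limits leave unreadable from compound 1 to compound 3 therefore cannot be read, because of the limit of > 50000 nM in this assay, at which 3 of the 3 values shown sit. Compound 2 `O=C(/C=C/c1ccc(OCCCCCCO[N+](=O)[O-])c(O)c1)OCCCCCCO[N+](=O)[O-]` likewise sits at the limit, giving > 50000 nM. The difference between the core of compound 2 and the core of compound 1 is not broken down here. Compound 4 `COc1cc(/C=C/C(=O)OCCCCCCO[N+](=O)[O-])ccc1OCCCCCCO[N+](=O)[O-]` has not been measured; it differs from compound 2 by methyl in place of hydrogen on an oxygen on an aromatic ring, the same change at the same place as from compound 1 to compound 3. Because compound 1 and compound 3 both stand at the limit of > 50000 nM in this assay, at which 3 of the 3 values shown sit, compound 4 is expected to remain at the limit too, with an estimated 80000 nM in this assay. The step this expectation implies is a step that the limit leaves unreadable from compound 2 to compound 4.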

Compound 4, half-maximal inhibitory concentration: > 50000 nM
Compound 4: a limit, no number; the forecaster's own chance of this, stated with the estimate: 85%; the middle value does not contradict the limit.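

Among these compounds, compound 2 and compound 4 both stand at a limit, so no step between them can be read: the limit of > 50000 nM in this assay, at which 4 of the 4 values shown sit. The compounds shown leave open whether methyl in place of hydrogen changes cytotoxicity in this series at all.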